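A few compounds are considered here, and "the series" means these few. Any claim that something is new, unique, unknown or untested is made for them only; others in the source may bear on it.

- Compound 1 `O=C(NCCCCn1cccn1)c1cccc(C2SCC(=O)N2c2cc(Br)ccn2)c1`: 105 nM
- Compound 2 `COc1ccccc1N1C(=O)CSC1c1cccc(C(=O)NCCCCn2cccn2)c1`: 91.7 nM

For the measured compounds named here, in a functional assay on HOS-TE85 cells (Homo sapiens) for inhibition, read by CCK-8 assay, with a stated time of 72 h (a higher number here means a weaker inhibitor, a lower number a stronger inhibitor), compound 2 gives 91.7 nM, within the scatter of compound 1, the only other compound measured. Compound 3 `O=C(NCCCCn1cccn1)c1cccc(C2SCC(=O)N2c2ccccn2)c1` has pyridin-2-yl in place of 2-methoxyphenyl on an amide-type nitrogen in a ring. Going by the values given here, one measured step bears on this place, a 1.1-fold lower number from compound 1 to compound 2 (0.06 log units; within the scatter), and it exchanged 4-bromopyridin-2-yl for 2-methoxyphenyl. With that step inside the scatter, no step beyond the scatter is expected in this assay. The estimated step is a 1.2-fold higher number from compound 2 to compound 3 (0.08 log units; within the scatter). Compound 3 is expected at 110 nM, with an estimated range of 45 nM to 270 nM.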

Compound 3, half-maximal inhibitory concentration: 60.3 nM
Compound 3: the middle estimate sits 1.8-fold (0.26 log units) above what was measured; the measured number falls inside the stated range.
By their numbers in this assay, from the lowest: compounds 3, 2 and 1 (each within the scatter of the next).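

In this assay, replacing the 2-methoxyphenyl with pyridin-2-yl on the amide-type nitrogen in a ring gives a 1.5-fold lower number from compound 2 to compound 3 (0.18 log units; within the scatter), and removing the bromo from the pyridine gives a 1.7-fold lower number from compound 1 to compound 3 (0.24 log units; within the scatter). All three groups tried at this place therefore lie within the scatter of one another, and the bromo is not required for activity in the nanomolar range seen here. Nothing available explains these small differences.

On these data alone, it remains open whether an amine or a carboxylic acid on this pyridine ring, or a plain methyl at this place, would move the number beyond the scatter.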